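Swapping the Carbamate Tail: Benzyl to Ethyl

The source may report more compounds than this note shows. Statements on the series, on what has been measured and on what is new or still open speak of the compounds shown alone.

Measured so far:
Compound 1, `CC(C)C(=O)OCOC(=O)N1CCN(C(=O)c2nc(Nc3cc(C4CC4)[nH]n3)c3cc(Cl)ccc3n2)C[C@H]1C`, gives 16.4%.
Compound 2, `C[C@@H]1CN(C(=O)c2nc(Nc3cc(C4CC4)[nH]n3)c3cc(Cl)ccc3n2)CCN1C(=O)OCc1ccccc1`, gives 4.4%.

Both measurements come from an assay for inhibition of serine/threonine-protein kinase PAK 4 (Homo sapiens), read by FRET and Z'-LYTE, with a stated time of 60 min, tested at 0.5 uM, in the presence of a further agent that is not named here; on this read-out lower numbers stand for a weaker effect and higher numbers for a stronger effect at the one concentration tested. Compound 2 stands lowest of the two numbers shown, and its nearest neighbour, compound 1, sits higher by a step that lies beyond the usual scatter.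

Among the measured compounds shown here, the only measured step, a number 12 percentage points lower from compound 1 to compound 2 (beyond the scatter), changes the group on a saturated chain carbon bound to an oxygen next to a carbonyl group, so it bears directly on the new compound. Compound 3, `CCOC(=O)N1CCN(C(=O)c2nc(Nc3cc(C4CC4)[nH]n3)c3cc(Cl)ccc3n2)C[C@H]1C`, changes the same position again: methyl in place of phenyl on a saturated chain carbon bound to an oxygen next to a carbonyl group. For the measured compounds named here, the one step shows that this position can move the read-out modestly, but it does not say which way a smaller group would move it, and both measured numbers are already low.

With that, compound 3 is expected to land close to compound 2, a step of a number 3.6 percentage points higher from compound 2 to compound 3 (within the scatter) within the scatter. The estimate for compound 3 in this assay is 8%, with a range from -2% to 22%.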

Compound 3, a percentage reported as inhibition, at one concentration (the size of the read-out at that concentration, not a potency): 42.4%
For compound 3 the middle estimate is 34.4 percentage points below the measured one; the whole stated range lies below it.
By their numbers in this assay, from the lowest: compound 2; then compound 1; then compound 3.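

The ethyl tail changes what this position appears able to do. In this assay methyl in place of phenyl gives a number 38 percentage points higher from compound 2 to compound 3 (beyond the scatter) as a large step, and methyl in place of (isopropylcarbonyl)oxy gives a number 26 percentage points higher from compound 1 to compound 3 (beyond the scatter) as a modest one, so the number depends strongly on what sits on this saturated chain carbon, and among these three carbamate tails the simple ethoxycarbonyl group gives the highest reading, with both steps beyond the usual scatter. No measurement shown here explains why the ethyl tail stands above the benzyl tail and the tail carrying (isopropylcarbonyl)oxy.

From the compounds shown here alone, with only three tails, no trend along the series can be drawn, and it remains open whether a longer chain such as propyl, a branched one such as isopropyl, or a chain ending in an amine or a carboxylic acid would keep, raise or lower the number. Each reading also comes from a single concentration, so these compounds show the size of the effect at that concentration and leave their potency open.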